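A few compounds are considered here, and "the series" means these few. Any claim that something is new, unique, unknown or untested is made for them only; others in the source may bear on it.

Within the data shown here, compound 2 `NCCNC(=O)c1c(O)c2ccccc2n(-c2ccccc2)c1=O` stands lowest of the two numbers so far: in a functional assay, with a stated time of 60 min, tested at 0.5 mM (a lower number here means a weaker effect, a higher number a stronger effect of the compound at the concentration tested), compound 2 gives 7.9%, whereas compound 1 `Cn1c(=O)c(C(=O)NCCN)c(O)c2ccccc21` gives 37.1%, a step of a number 29.2 percentage points lower from compound 1 to compound 2 (beyond the scatter). Compound 3 `O=C(CCCCC1CCSS1)NCCNC(=O)c1c(O)c2ccccc2n(-c2ccccc2)c1=O` differs from compound 2 in one place: a group of 11 heavy atoms (8 carbon, 1 oxygen, 2 sulfur; one five-membered non-aromatic ring with 2 hetero atoms) in place of a hydrogen atom, on an amine nitrogen. Among the measured compounds shown here, the single measured step, phenyl in place of methyl on an aromatic nitrogen, concerns a different position, so no measured step bears on this change and its direction cannot be read from the data. With little to go on, compound 3 is expected to move only slightly, a step of a number 6.1 percentage points higher from compound 2 to compound 3 (within the scatter), and is estimated at 14%, between 0% and 40%.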

Compound 3, a percentage reported as activity, at one concentration (the size of the read-out at that concentration, not a potency): 14.1%
Beside the measured number, compound 3's estimate is 0.1 percentage points below it; measured number inside the range.
By their numbers in this assay, from the lowest: compounds 2 and 3 (each within the scatter of the next); then compound 1.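

At this amine nitrogen, the first position where the compounds shown differ on the side chain, the group of 11 heavy atoms in place of a hydrogen atom gives a step in this assay of a number 6.2 percentage points higher from compound 2 to compound 3 (within the scatter), so the readings for the two compounds cannot be told apart. No measured evidence bears on this result.

Going by these compounds, it remains open whether a carboxylic acid or a longer chain on this amine nitrogen would read differently. Also open, on these data alone, is how the same group would read with methyl in place of phenyl on the aromatic nitrogen.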